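From compound 2 to compound 3: a benzyl exchange

The source may hold more compounds than are shown below. What is called first, only, known or untested is meant among the compounds shown, and "the series" means these compounds.

compound 1, `O=C(c1ccc[n+](Cc2ccccc2)c1)N1CCN(c2ccccc2Cl)CC1`: 89%
compound 2, `O=C(C1CCCN(Cc2ccccc2F)C1)N1CCN(c2ccccc2Cl)CC1`: 50%

In a functional assay on a cell-free system (Platelet, plasma, Homo sapiens), with stated times of 4 min and 5.5 min, tested at 1 uM (a lower number here means a stronger effect, a higher number a weaker effect of the compound at the concentration tested), compound 1 gives 89%, while compound 2 gives 50%. Compound 2 stands at the lowest of the two numbers; its nearest neighbour is compound 1, whose number lies higher by a margin beyond the usual scatter, so of these two compound 2 shows the stronger effect at the concentration tested. Going by the values given here, no pair of measured compounds differs in only one place, so no single-change step is available to lean on.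

Compound 3, `O=C(C1CCCN(Cc2ccc(Br)cc2)C1)N1CCN(c2ccccc2Cl)CC1`, has not yet been measured. It differs from compound 2 in one place: 4-bromophenyl in place of 2-fluorophenyl on a saturated chain carbon bound to an amine nitrogen in a ring. Among the compounds with values here, nothing among the measured compounds shows what replacing 2-fluorobenzyl by 4-bromobenzyl does here, so only a modest step is expected, in either direction and quite possibly none beyond the scatter. The step expected for compound 3 is a number 5 percentage points higher from compound 2 to compound 3 (within the scatter). For compound 3 the estimated value is 55%, with a range from 30% to 80%.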

Compound 3, a percentage reported as activity, at one concentration (the size of the read-out at that concentration, not a potency): 39%
Compound 3: middle estimate off by 16 percentage points, on the high side, and the stated range covers the measured number.
By their numbers in this assay, from the lowest: compound 3; then compound 2; then compound 1.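

In this assay, going by these compounds alone, the exchange of 2-fluorophenyl for 4-bromophenyl on a saturated chain carbon bound to an amine nitrogen in a ring gives the first single-change step in this set, with a number 11 percentage points lower from compound 2 to compound 3 (beyond the scatter) and thus a modest gain in effect at the concentration tested. This shows that the position responds to what the aromatic ring carries, although the two groups match in everything counted here: each has 7 heavy atoms, one six-membered aromatic ring of carbon only, no hydrogen-bond donors or acceptors and no net charge. Nothing measured here bears on why the number falls with this exchange.

The single step changes both the halogen and its place on the ring, so the compounds shown cannot say which of the two carries the gain. They also leave open how the series would respond to a chlorine, a methoxy group or a carboxylic acid on this ring, or to a longer chain between the ring and the amine nitrogen.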